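A few compounds are considered here, and "the series" means these few. Any claim that something is new, unique, unknown or untested is made for them only; others in the source may bear on it.

In a functional assay on MCF7 cells (Homo sapiens) for cytotoxicity, read by MTT assay, with a stated time of 96 h (on this read-out lower numbers stand for stronger inhibition and higher numbers for weaker inhibition), compound 1 (`COc1cc(C(=O)c2cn(-c3cccc(N)c3)cc2-c2cccc(N)c2)cc(OC)c1OC`) gives 60 nM and compound 2 (`COc1cc(C(=O)c2cn(-c3ccc(N)cc3)cc2-c2ccccc2[N+](=O)[O-])cc(OC)c1OC`) gives 53 nM on the same scale. Compound 2 therefore stands level with compound 1, the two values lying within the scatter of each other. Compound 3 (`COc1cc(C(=O)c2cn(-c3ccc(N)cc3)cc2-c2cccc(N)c2)cc(OC)c1OC`) differs from compound 2 in one place (3-aminophenyl in place of 2-nitrophenyl on an aromatic carbon): 3-aminophenyl in place of 2-nitrophenyl on an aromatic carbon, two ring bonds from the ring atom that bears a 4-aminophenyl group. Within the data shown here, no measured pair isolates this change. Compound 1 also bears a 3-aminophenyl group and has no 2-nitrophenyl group, yet gives 60 nM in this range, so no step beyond the scatter is expected in this assay from this exchange. The estimated move is small (a 1.3-fold lower number from compound 2 to compound 3 (0.12 log units; within the scatter)) and points slightly toward a lower number. For compound 3 the expected value is 40 nM with an estimated range of 12 nM to 130 nM for repeat measurements.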

Compound 3, half-maximal inhibitory concentration: 78 nM
For compound 3 the middle estimate is 2.0-fold (0.29 log units) below the measured one; measured number inside the range.
By their numbers in this assay, from the lowest: compounds 2, 1 and 3 (each within the scatter of the next).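

In this assay, 3-aminophenyl in place of 2-nitrophenyl on the aromatic carbon of the five-membered ring gives a 1.5-fold higher number from compound 2 to compound 3 (0.17 log units; within the scatter), so the two groups are not told apart at this position despite their different heavy-atom and hydrogen-bond donor counts. Among these compounds, the same compound also gives the first reading on the ring nitrogen: 4-aminophenyl in place of 3-aminophenyl there gives a 1.3-fold higher number from compound 1 to compound 3 (0.11 log units; within the scatter), so these two aminophenyl groups are likewise not told apart in this assay. Nothing available here accounts for either result.

As far as these compounds go, all three compounds carry only aminophenyl or nitrophenyl groups at these two places, so the limits of this flat range remain open. From the compounds shown here alone, whether a methyl group or a carboxylic acid at either place would produce a step beyond the scatter also stays open.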